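The source may hold more compounds than are shown below. What is called first, only, known or untested is meant among the compounds shown, and "the series" means these compounds.

Compound 2 `COc1ccc(F)cc1CNCCCNc1ccnc2cc(Cc3ccccc3)ccc12` has been tested in an ADME assay for permeability, using PAMPA, with a stated time of 30 min, at pH 7.4 (on this read-out higher numbers stand for higher permeability and lower numbers for lower permeability), where compound 2 gives 23 10^-6 cm/s. Compound 1 `c1ccc(Cc2ccc3c(NCCCNCc4ccco4)ccnc3c2)cc1` gives 23 10^-6 cm/s in this assay. Compound 3 `c1coc(CNCCCNc2ccnc3cc(CC4CCCCC4)ccc23)c1` gives 23 10^-6 cm/s, so compound 2 stands level with both. The two steps measured so far, no change at the digits printed from compound 1 to compound 2 (within the scatter) and no change at the digits printed from compound 1 to compound 3 (within the scatter), stayed within the scatter. Compound 4 `COc1ccc(F)cc1CNCCCNc1ccnc2cc(-c3cccc4ccccc34)ccc12` has not yet been measured; its change from compound 2 is naphthalen-1-yl in place of benzyl on an aromatic carbon. Among the measured compounds shown here, the nearest precedent is the step from compound 1 to compound 3, which exchanged cyclohexyl for phenyl on a saturated chain carbon bound to an aromatic carbon and left permeability unchanged; no measured step has put a ring directly on an aromatic carbon of the core. The expected step is therefore a 1.0-fold lower number from compound 2 to compound 4 (0.02 log units; within the scatter), within the scatter. Compound 4 is expected to give about 22 10^-6 cm/s, between 11 10^-6 cm/s and 40 10^-6 cm/s.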

Compound 4, apparent permeability: 237 10^-6 cm/s
For compound 4 the middle estimate is 11-fold (1.03 log units) below the measured one; measured number above the stated range.
By their numbers in this assay, from the lowest: compounds 1, 2 and 3 (each within the scatter of the next); then compound 4.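

In this assay, the aromatic carbon carrying these groups responds strongly to what is attached there, with naphthalen-1-yl in place of benzyl giving a 10-fold higher number from compound 2 to compound 4 (1.01 log units; beyond the scatter). Changing the ring of the group at this place had earlier produced no change at the digits printed from compound 1 to compound 3 (within the scatter), so the read-out here is not indifferent to every change. No measurement on hand explains the rise. The swap removes the benzyl chain carbon and adds a second ring at once, leaving their shares unresolved. A phenyl or naphthalen-2-yl group on that aromatic carbon could separate them.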